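The source may report more compounds than this note shows. Statements on the series, on what has been measured and on what is new or still open speak of the compounds shown alone.

Measured in a functional assay on HT-29 cells (Homo sapiens) for inhibition, read by MTT assay, with a stated time of 48 h; a higher number here means a weaker inhibitor, a lower number a stronger inhibitor:
- compound 1 `COc1ccc(C(=O)CSc2nnc(-c3cc(OC)c(OC)c(OC)c3)n2-c2ccc(OC)cc2)cc1`: > 60000 nM (a limit of the assay, not a number)
- compound 2 `COc1cc(-c2nnc(SC)n2-c2ccc(N(C)C)cc2)cc(OC)c1OC`: > 60000 nM (a limit of the assay, not a number)
- compound 3 `COc1cc(-c2nnc(SCC(=O)c3ccccc3)n2-c2ccc(N(C)C)cc2)cc(OC)c1OC`: 45200 nM

Going by the values given here, compound 3 holds the only actual number in this assay (45200 nM). The other two compounds stop at the same limit (the limit of > 60000 nM in this assay, at which 2 of the 3 values shown sit).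

The next compound, compound 4 `COc1ccc(C(=O)CSc2nnc(-c3cc(OC)c(OC)c(OC)c3)n2-c2ccc(N(C)C)cc2)cc1`, differs from compound 3 in one place: methoxy replaces hydrogen on an aromatic carbon (methoxy in place of hydrogen on an aromatic carbon), turning benzoyl into (4-methoxyphenyl)carbonyl. Among the compounds with values here, the one measured step bearing on this is the addition of benzoyl (an at least 1.3-fold lower number from compound 2 to compound 3 (0.12 log units; that floor lies within the scatter)). That step concerns a different change and stays within the scatter. Compound 1 also carries (4-methoxyphenyl)carbonyl but differs elsewhere too, and its result is a limit (> 60000 nM).

With so little to go on, no shift beyond the scatter is expected, and the estimated step is small (a 1.3-fold lower number from compound 3 to compound 4 (0.11 log units; within the scatter)). The estimated value for compound 4 is 35000 nM (range 8000 nM to 60000 nM).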

Compound 4, half-maximal inhibitory concentration: 64000 nM
For compound 4 the middle estimate is 1.8-fold (0.26 log units) below the measured one, and the stated range ends below it.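

In this assay the first direct test of this position, which turns benzoyl into (4-methoxyphenyl)carbonyl by placing methoxy on an aromatic carbon para to a large group, gives a 1.4-fold higher number from compound 3 to compound 4 (0.15 log units; within the scatter) and therefore no real change. On this evidence, with the rest of the molecule held fixed, adding methoxy here neither clearly helps nor clearly harms. The steps to compound 4 from compound 2 and from compound 1 cannot be read, because each starts from a limit of the assay and not a number: the limit of > 60000 nM in this assay, at which 2 of the 4 values shown sit.

Going by these compounds, whether a different group at this place, such as an amine, a carboxylic acid or a longer alkoxy chain, would move the number beyond the scatter remains open. Also open, on these data alone, is whether dimethylamino in place of methoxy on the other aromatic ring matters at all.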